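Aryl exchange from compound 3 to compound 4

The compounds below may be only part of what the source reports. "The series", "measured", "known", "first", "only" and "open" are said of these compounds alone.

In a functional assay on HeLa cells (Homo sapiens) for cytotoxicity, read by MTT assay, with a stated time of 48 h (on this read-out higher numbers stand for weaker inhibition and lower numbers for stronger inhibition), compound 1 `CC(C)=CCC/C(C)=C/CC/C(C)=C/CC[C@@H]1[C@@]2(C)C/C(=C\c3ccc(OCc4cn(-c5ccc(Cl)cc5)nn4)cc3)C(=O)C(C)(C)[C@@H]2CC[C@@]1(C)O` gives 50700 nM and compound 2 `CC(C)=CCC/C(C)=C/CC/C(C)=C/CC[C@@H]1[C@@]2(C)C/C(=C\c3ccc(OCc4cn(-c5cccc([N+](=O)[O-])c5)nn4)cc3)C(=O)C(C)(C)[C@@H]2CC[C@@]1(C)O` gives 32900 nM while compound 3 `CC(C)=CCC/C(C)=C/CC/C(C)=C/CC[C@@H]1[C@@]2(C)C/C(=C\c3ccc(OCc4cn(-c5cccc(C(F)(F)F)c5)nn4)cc3)C(=O)C(C)(C)[C@@H]2CC[C@@]1(C)O` gives 17300 nM on this read-out. Going by the values given here, only one step clears the scatter (a 2.9-fold lower number from compound 1 to compound 3 (0.47 log units; beyond the scatter)) and the other two do not (a 1.5-fold lower number from compound 1 to compound 2 (0.19 log units; within the scatter)) and (a 1.9-fold lower number from compound 2 to compound 3 (0.28 log units; within the scatter)). Compound 3 thus stands clear of compound 1 only, not of compound 2.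

Compound 4 `CC(C)=CCC/C(C)=C/CC/C(C)=C/CC[C@@H]1[C@@]2(C)C/C(=C\c3ccc(OCc4cn(-c5c(Cl)cc([N+](=O)[O-])cc5Cl)nn4)cc3)C(=O)C(C)(C)[C@@H]2CC[C@@]1(C)O` differs from compound 3 at one place (2,6-dichloro-4-nitrophenyl in place of 3-(trifluoromethyl)phenyl on an aromatic nitrogen). Among the compounds with values here, no measured compound carries this aryl group. The widest aryl exchange so far (a 2.9-fold lower number from compound 1 to compound 3 (0.47 log units; beyond the scatter)) is modest, so no step beyond the scatter is expected in this assay, at most a small rise. The expected step is (a 1.6-fold higher number from compound 3 to compound 4 (0.21 log units; within the scatter)). Compound 4 is estimated at 28000 nM with an expected range from 12000 nM to 65000 nM for now.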

Compound 4, half-maximal inhibitory concentration: 36900 nM
Compound 4: the middle estimate sits 1.3-fold (0.12 log units) below what was measured, within the range that was stated.
By their numbers in this assay, from the lowest: compounds 3, 2, 4 and 1 (each within the scatter of the next, the first and the last beyond it).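

In this assay, 2,6-dichloro-4-nitrophenyl on the aromatic nitrogen falls behind 3-(trifluoromethyl)phenyl (a 2.1-fold higher number from compound 3 to compound 4 (0.33 log units; beyond the scatter)), yet it cannot be told apart from 3-nitrophenyl (a 1.1-fold higher number from compound 2 to compound 4 (0.05 log units; within the scatter)) or 4-chlorophenyl (a 1.4-fold lower number from compound 1 to compound 4 (0.14 log units; within the scatter)). This position therefore accepts an aryl group with chlorine next to the ring nitrogen without a step beyond the scatter against two of the three earlier aryl groups. No supporting measurement accounts for the step from compound 3.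

From the compounds shown here alone, whether an amine or a carboxylic acid on this aryl ring, or a longer chain in its place, would shift the number in this assay stays open.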